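Pyridin-4-yl for 2,4,6-trimethoxyphenyl on a triazole

The source may report more compounds than this note shows. Statements on the series, on what has been measured and on what is new or still open speak of the compounds shown alone.

Measured in a functional assay on DU-145 cells (Homo sapiens) for cytotoxicity, read by MTT assay, with a stated time of 48 h; a lower number here means a stronger inhibitor, a higher number a weaker inhibitor:
compound 1, `COc1cc(OC)c(-n2cc(CO/N=C3\CC[C@]4(C)[C@@H](CC/C=C(\C)CC/C=C(\C)CCC=C(C)C)[C@](C)(O)CC[C@H]4C3(C)C)nn2)c(OC)c1`, gives 11100 nM
compound 2, `CC(C)=CCC/C(C)=C/CC/C(C)=C/CC[C@@H]1[C@@]2(C)CC/C(=N\OCc3cn(-c4ccncc4)nn3)C(C)(C)[C@@H]2CC[C@@]1(C)O`, gives 17400 nM
compound 3, `COc1cc(OC)c(-n2cc(COc3ccc(/C=C4\C[C@]5(C)[C@@H](CC/C=C(\C)CC/C=C(\C)CCC=C(C)C)[C@](C)(O)CC[C@H]5C(C)(C)C4=O)cc3)nn2)c(OC)c1`, gives 12000 nM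

Compounds 1 and 2 share one core and differ in a single place: pyridin-4-yl in place of 2,4,6-trimethoxyphenyl on an aromatic nitrogen. In this assay this gave a 1.6-fold higher number from compound 1 to compound 2 (0.20 log units; within the scatter), so the two numbers are not separated by more than the usual variation of repeated measurements.

Compound 3 carries a different core; how it differs from compound 1 is not broken down here. Its value in this assay lies close to that of compound 1, and the two are within scatter of each other.

Compound 4, `CC(C)=CCC/C(C)=C/CC/C(C)=C/CC[C@@H]1[C@@]2(C)C/C(=C\c3ccc(OCc4cn(-c5ccncc5)nn4)cc3)C(=O)C(C)(C)[C@@H]2CC[C@@]1(C)O`, has not yet been measured. It differs from compound 3 in one place: pyridin-4-yl in place of 2,4,6-trimethoxyphenyl on an aromatic nitrogen. The surroundings of the change are described in the same words as for the step from compound 1 to compound 2, so this is the same change made on the second core.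

Among the compounds with values here, because a 1.6-fold higher number from compound 1 to compound 2 (0.20 log units; within the scatter) was seen for the one measured instance of this change, the account expects a similar small step for compound 4, namely a 1.5-fold higher number from compound 3 to compound 4 (0.18 log units; within the scatter). Within the data shown here, with only one prior instance, the expectation is held loosely. Compound 4 is accordingly estimated at 18000 nM in this assay, within a range of 9000 nM to 36000 nM.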

Compound 4, half-maximal inhibitory concentration: 25700 nM
Beside the measured number, compound 4's estimate is 1.4-fold (0.15 log units) below it, and the stated range covers the measured number.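

On the second core, pyridin-4-yl in place of 2,4,6-trimethoxyphenyl on an aromatic nitrogen gave a 2.1-fold higher number from compound 3 to compound 4 (0.33 log units; beyond the scatter) in this assay. Set beside the earlier instance, both steps run in the same direction and their sizes cannot be told apart, so in these compounds the change carries from one core to the other with much the same outcome: the same change on two cores in this assay, a 1.6-fold higher number (0.20 log units; within the scatter) from compound 1 to compound 2 and a 2.1-fold higher number (0.33 log units; beyond the scatter) from compound 3 to compound 4, 1.4-fold (0.14 log units) apart, within the scatter of two such steps. Within the data shown here, this does not show a firm or general transfer, since only the step on the second core lies beyond the scatter, and then only modestly, and two cores are a narrow base that says nothing about any further core or about why the numbers move.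

The compounds shown have only these two groups on the aromatic nitrogen, so it remains open how a plain phenyl, a benzyl or a pyridin-3-yl would read on either core. As far as these compounds go, it is also open whether the same step would appear if the long unsaturated side chain shared by all four compounds gave way to a shorter saturated alkyl chain, or if an amine or a carboxylic acid stood on the ring that enters.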